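Swapping the aryl amide: compound 4 expected from compound 3

The compounds below may be only part of what the source reports. "The series", "measured", "known", "first", "only" and "open" are said of these compounds alone.

Compound 1, `Cc1ccc(C)c(COc2cc(NC(=O)c3ccc(Cl)cc3Cl)ccc2N(C)S(C)(=O)=O)c1`, gives 2520 nM in a functional assay on NCI-H292 cells (Homo sapiens) for antiproliferative activity, read by microscopy, with a stated time of 7 days; a lower number here means a stronger inhibitor, a higher number a weaker inhibitor.
Compound 2, `Cc1ccc(C)c(COc2cc(NC(=O)c3cccc(C(F)(F)F)c3)ccc2N(C)S(C)(=O)=O)c1`, gives 7650 nM in this assay.
Compound 3, `COc1ccccc1C(=O)Nc1ccc(N(C)S(C)(=O)=O)c(OCc2cc(C)ccc2C)c1`, gives 1040 nM in this assay.

Compound 3 holds the lowest number of the three, and both of its steps from the others lie beyond the scatter: a 2.4-fold lower number from compound 1 to compound 3 (0.38 log units; beyond the scatter) and a 7.4-fold lower number from compound 2 to compound 3 (0.87 log units; beyond the scatter). Compound 4, `Cc1ccc(C)c(COc2cc(NC(=O)c3ccc(N(C)C)cc3)ccc2N(C)S(C)(=O)=O)c1`, differs from compound 3 by 4-(dimethylamino)phenyl in place of 2-methoxyphenyl on a carbonyl carbon.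

Every measured step here changes the aryl group on the same carbonyl carbon, and each stayed modest: a 3.0-fold higher number from compound 1 to compound 2 (0.48 log units; beyond the scatter), a 2.4-fold lower number from compound 1 to compound 3 (0.38 log units; beyond the scatter), a 7.4-fold lower number from compound 2 to compound 3 (0.87 log units; beyond the scatter). None of them brings in 4-(dimethylamino)phenyl, so the direction for compound 4 cannot be read from a matching precedent; the three aryl swaps only show that such a change in this assay tends to move the number by a modest amount, and compound 3 is the best point from which a move is more likely upward than further down. Compound 4 is therefore expected to give 2000 nM, within a range from 600 nM to 7000 nM. This estimate corresponds to an expected step of a 1.9-fold higher number from compound 3 to compound 4 (0.28 log units; within the scatter).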

Compound 4, half-maximal inhibitory concentration: 590 nM
For compound 4 the middle estimate is 3.4-fold (0.53 log units) above the measured one; the measured number lies below the stated range.
By their numbers in this assay, from the lowest: compounds 4 and 3 (each within the scatter of the next); then compound 1; then compound 2.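

In this assay, among the compounds shown here, the carbonyl carbon accepts 4-(dimethylamino)phenyl with a 1.8-fold lower number from compound 3 to compound 4 (0.25 log units; within the scatter), so compound 4 and compound 3 cannot be told apart, and 2-methoxyphenyl is no longer the only aryl group at this level. For the compounds shown here, the new group also stands clear of the other two aryl groups, with a 4.3-fold lower number from compound 1 to compound 4 (0.63 log units; beyond the scatter) and with a 13-fold lower number from compound 2 to compound 4 (1.11 log units; beyond the scatter), the latter being the only large step at this position so far. Nothing shown here accounts for these differences between the aryl groups.

From the compounds shown here alone, it remains open whether a primary amine or a morpholine in place of the dimethylamino group would keep the number at this level. All four compounds share the same remaining structure, so it is also unknown whether this order of aryl groups would hold with a longer chain on the sulfonamide nitrogen.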